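The compounds below may be only part of what the source reports. "The series", "measured", "known", "first", "only" and "open" are said of these compounds alone.

Measured compounds in a functional assay on SK-OV-3 cells (Homo sapiens) for inhibition, read by CCK-8 assay, with a stated time of 70 h; a lower number here means a stronger inhibitor, a higher number a weaker inhibitor:
compound 1 `c1ccc(COc2ccc(OCCOCCOC3CCCC3)cc2)cc1` gives > 100000 nM, a limit of the assay.
compound 2 `COc1ccc(COc2ccc(OCCOCCNC3CCCC3)cc2)cc1` gives 15700 nM.
compound 3 `Nc1ccc(COc2ccc(OCCOCCNC3CCCC3)cc2)cc1` gives 31700 nM.

Compound 1 stands only at the limit (the limit of > 100000 nM in this assay, at which 1 of the 3 values shown sits); no number is known for it. Compound 4 `c1ccc(COc2ccc(OCCOCCNC3CCOC3)cc2)cc1` differs from compound 1 by (oxolan-3-yl)amino in place of cyclopentyloxy on a saturated chain carbon, two bonds along the chain from an oxygen on a saturated carbon. Going by the values given here, the one measured step, a 2.0-fold higher number from compound 2 to compound 3 (0.31 log units; beyond the scatter), concerns a substituent on an aromatic carbon and does not touch the chain end, so it bears little on this change. Compounds 2 and 3, which carry an amine at that chain end, both give measurable numbers. Compound 1, with the ether, gives only a limit. Compound 4 brings in an amine too, so compound 4 is expected to fall inside the range of the assay, estimated at 25000 nM (range 6000 nM to 90000 nM), meaning an expected at least 4.0-fold lower number from compound 1 to compound 4 (0.60 log units; beyond the scatter).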

Compound 4, half-maximal inhibitory concentration: 48000 nM
Compound 4: the middle estimate sits 1.9-fold (0.28 log units) below what was measured; low and high end bracket the measured number.
By their numbers in this assay, from the lowest: compound 2; then compounds 3 and 4 (each within the scatter of the next). At a limit, above all of these: compound 1.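

In this assay, (oxolan-3-yl)amino in place of cyclopentyloxy on a saturated chain carbon, two bonds along the chain from an oxygen on a saturated carbon, gives an at least 2.0-fold lower number from compound 1 to compound 4 (0.31 log units; beyond the scatter). Going by these compounds alone, this is the first readable step at this position, and it replaces a limit with a number. Compound 1 remains a limit, so the step gives only a bound on the size of the change: the limit of > 100000 nM in this assay, at which 1 of the 4 values shown sits.

Open, going by these compounds, is whether the amine nitrogen or the ring oxygen of the entering group carries the step. Cyclopentylamino on the core of compound 1 would separate the two.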